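Working notes: from compound 3 to its chloro analogue

The source may hold more compounds than are shown below. What is called first, only, known or untested is meant among the compounds shown, and "the series" means these compounds.

Compound 1 `CCCS(=O)(=O)N1CCC(CNC(=O)C2CC2)(C(=O)N2CCOCC2)CC1`: 0.3 h
Compound 2 `CCCS(=O)(=O)N1CCC(CNC(=O)c2ccccc2OC(F)(F)F)(C(=O)N2CCOCC2)CC1`: 0.3 h
Compound 3 `CCCS(=O)(=O)N1CCC(CNC(=O)c2c(F)cccc2F)(C(=O)N2CCOCC2)CC1`: 0.3 h

Level with compound 1 and compound 2 in an ADME assay on the whole organism for metabolic stability, with Rattus norvegicus as the target (a higher number here means that the compound lasts longer, a lower number that the compound disappears faster), compound 3 gives 0.3 h. Compound 4 `CCCS(=O)(=O)N1CCC(CNC(=O)c2c(F)ccc(Cl)c2F)(C(=O)N2CCOCC2)CC1` has chloro in place of hydrogen on an aromatic carbon, turning 2,6-difluorophenyl into 3-chloro-2,6-difluorophenyl (chloro in place of hydrogen on an aromatic carbon). The measured steps on this carbonyl substituent are no change at the digits printed from compound 1 to compound 2 (within the scatter), no change at the digits printed from compound 1 to compound 3 (within the scatter) and no change at the digits printed from compound 2 to compound 3 (within the scatter). Among the measured compounds shown here, none goes beyond the scatter, though no measured compound carries chloro, so the evidence is indirect. No step beyond the scatter is expected, in either direction: the estimated step is no change at the digits printed from compound 3 to compound 4 (within the scatter). The estimate for compound 4 is 0.3 h, with an expected range of 0.2 h to 0.6 h.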

Compound 4, half-life: 0.3 h
Compound 4: middle estimate and measured number agree at the digits printed, and the stated range covers the measured number.
By their numbers in this assay, from the lowest: compounds 1, 2, 3 and 4 (each within the scatter of the next).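

Chloro on this aromatic ring, ortho to a fluoro group and para to a fluoro group, now has a direct reading in this assay (no change at the digits printed from compound 3 to compound 4 (within the scatter)). The 3-chloro-2,6-difluorophenyl group also stands level with the two other carbonyl substituents (no change at the digits printed from compound 2 to compound 4 (within the scatter)) and (no change at the digits printed from compound 1 to compound 4 (within the scatter)). No measurement at hand accounts for this result.

As far as these compounds go, it remains open whether an amine or a carboxylic acid on this aromatic ring would shift the half-life. From the compounds shown here alone, it also remains open whether a longer chain in place of propyl on the shared core would do so.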